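This account rests on a few compounds, and the source may have more. Where it says the series, first, only, none or still open, it means among the compounds named here.

Measured compounds in the series:
compound 1, `O=C(NCCCNc1nc(Nc2cccc(F)c2)ncc1C1CC1)C1CCC1`, in an assay on isolated protein for inhibition of serine/threonine-protein kinase TBK1 (Homo sapiens) (a lower number here means a stronger inhibitor, a higher number a weaker inhibitor), compound 1 gives 8 nM.
compound 2, `CC(C)c1cnc(Nc2cccc(F)c2)nc1NCCCNC(=O)C1CCC1`, for compound 2 only a limit is reported, > 1000 nM.
compound 3, `CN1CCC(c2ccc(Nc3ncc(C4CC4)c(NCCCNC(=O)C4CCC4)n3)cc2)CC1`, in this assay compound 3 gives 8 nM.

Compound 2 stands at the weak end of the three shown values: its result is a limit, not a number (the limit of > 1000 nM in this assay, at which 1 of the 3 values shown sits). Going by the values given here, the one step that reaches it, an at least 120-fold higher number from compound 1 to compound 2 (2.09 log units; beyond the scatter), is large and beyond the scatter, so the substituent on the aromatic carbon of the shared core clearly matters. Compound 1 and compound 3 sit within the scatter of each other.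

The next compound, compound 4, `CCc1cnc(Nc2cccc(F)c2)nc1NCCCNC(=O)C1CCC1`, differs from compound 2 by hydrogen in place of methyl on a saturated chain carbon bound to an aromatic carbon and a saturated chain carbon. Among the compounds with values here, this cuts the branched group back toward the size of the cyclopropyl that compound 1 carries, so some of the loss seen in an at least 120-fold higher number from compound 1 to compound 2 (2.09 log units; beyond the scatter) is expected to be recovered in this assay, though how much is open, since the only measured step spans cyclopropyl against isopropyl and not ethyl. The expected step is an at least 5.0-fold lower number from compound 2 to compound 4 (0.69 log units; beyond the scatter). For compound 4 the estimated value in this assay is 200 nM, within 30 nM to 1000 nM.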

Compound 4, half-maximal inhibitory concentration: 63 nM
Compound 4: the middle estimate sits 3.2-fold (0.50 log units) above what was measured; measured number inside the range.
By their numbers in this assay, from the lowest: compounds 1 and 3 (each within the scatter of the next); then compound 4. At a limit, above all of these: compound 2.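

Cutting isopropyl back to ethyl gives an at least 15-fold lower number from compound 2 to compound 4 (1.20 log units; beyond the scatter) in this assay, so a single methyl at this place separates a measurable inhibitor from one beyond the range of the assay. Compound 2 is reported only as a limit, so that step has a bound and not a size: the limit of > 1000 nM in this assay, at which 1 of the 4 values shown sits. Ethyl does not replace cyclopropyl in full, with a 7.9-fold higher number from compound 1 to compound 4 (0.90 log units; beyond the scatter), which puts the three groups on this aromatic carbon in the order cyclopropyl, ethyl, isopropyl from the lowest number to the highest.

Going by these compounds, how hydrogen, methyl or n-propyl on this aromatic carbon would rank against these three groups remains open. Also open is whether the same order holds with the substituted aryl amine of compound 3, which is shown here only with cyclopropyl.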